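A few compounds are considered here, and "the series" means these few. Any claim that something is new, unique, unknown or untested is made for them only; others in the source may bear on it.

Measured so far:
compound 1, `Nc1scc(CN2CCN(c3ccc([N+](=O)[O-])cc3)CC2)c1C(=O)c1ccc(Cl)cc1`: -12%
compound 2, `Nc1scc(CN2CCN(c3cccc(F)c3)CC2)c1C(=O)c1cccc(C(F)(F)F)c1`: -11%

Both measurements come from a functional assay on CHO cells with adenosine receptor A1 (Homo sapiens) as the target, read by cAMP accumulation and immunoassay, with a stated time of 6 min, tested at 0.01 uM; on this read-out lower numbers stand for a stronger effect and higher numbers for a weaker effect at the one concentration tested. In this assay compound 1 gives -12% and compound 2 gives -11%. The two numbers lie within the usual scatter of each other, so the data do not set one compound apart from the other; both show only a weak effect at the single concentration tested, and compound 1 simply stands as one of two near-identical read-outs.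

The next compound, compound 3, `Nc1scc(CN2CCN(c3ccccc3F)CC2)c1C(=O)c1ccc(Cl)cc1`, keeps the shared core of compound 1 and changes a single place: 2-fluorophenyl in place of 4-nitrophenyl on an amine nitrogen in a ring. Compound 2 already carries a fluorophenyl on the same ring nitrogen, with the fluorine in another position and a different group on the carbonyl side, and its number in this assay is not distinguishable from that of compound 1. Among the compounds with values here, no step between measured compounds has been established here, so there is no measured precedent for the exchange of a nitro-bearing ring for a fluorine-bearing one.

The step from compound 1 to compound 3 is therefore expected to be small, a number 4 percentage points higher from compound 1 to compound 3 (within the scatter), in no particular direction, and not beyond the scatter. Compound 3 is estimated to give -8% in this assay, within a range from -25% to 10%.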

Compound 3, a percentage reported as activity, at one concentration (the size of the read-out at that concentration, not a potency): 2.1%
The estimate for compound 3 lay 10.1 percentage points below the measured number, within the range that was stated.
By their numbers in this assay, from the lowest: compounds 1 and 2 (each within the scatter of the next); then compound 3.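

The exchange of 4-nitrophenyl for 2-fluorophenyl on an amine nitrogen in a ring gives a number 14.1 percentage points higher from compound 1 to compound 3 (beyond the scatter) in this assay and so shifts the read-out toward a weaker effect at the one concentration tested. Within the data shown here, this is the only step at hand that changes a single place, and it shows that the group on this ring nitrogen can alter the read-out while the rest of the core of compound 1 stays the same. Nothing measured here explains why the read-out shifts with this exchange.

Because the two rings differ in both their substituent and where it sits, this single step cannot show whether the departure of the nitro group or the arrival of the fluorine matters more, or whether the location of the substituent on the ring plays a part. Also open, on these data alone, is how this read-out would respond to a plain phenyl, a 4-fluorophenyl or a 4-methoxyphenyl on the same nitrogen, and whether the shift would hold at other concentrations.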